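Removing the acetyl from the chain of compound 3

The compounds below may be only part of what the source reports. "The series", "measured", "known", "first", "only" and "open" are said of these compounds alone.

Three compounds have been measured in an in vitro assay on Sf9 cells for inhibition of cytochrome P450 2J2 (Homo sapiens); on this read-out lower numbers stand for stronger inhibition and higher numbers for weaker inhibition:

Compound 1 `COc1ccc(C(=O)CCCN2CCC(C(O)(c3ccccc3)c3ccccc3)CC2)cc1`: 7600 nM
Compound 2 `C=CCc1ccc(C(=O)CCCN2CCC(C(O)(c3ccccc3)c3ccccc3)CC2)cc1`: 400 nM
Compound 3 `CC(=O)OCCCc1ccc(C(=O)CCCN2CCC(C(O)(c3ccccc3)c3ccccc3)CC2)cc1`: 2500 nM

All three share the same core and differ only in one group on an aromatic carbon. Compound 3 gives the second highest number of the three: a 3.0-fold lower number from compound 1 to compound 3 (0.48 log units; beyond the scatter), while a 6.3-fold higher number from compound 2 to compound 3 (0.80 log units; beyond the scatter).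

Compound 4 `O=C(CCCN1CCC(C(O)(c2ccccc2)c2ccccc2)CC1)c1ccc(CCCO)cc1` has not been measured. It differs from compound 3 by hydrogen in place of acetyl on an oxygen on a saturated carbon. Going by the values given here, no measured step removes an acetyl from an oxygen, so there is no direct precedent. The two steps that build or alter the acetoxy chain, a 3.0-fold lower number from compound 1 to compound 3 (0.48 log units; beyond the scatter) and a 6.3-fold higher number from compound 2 to compound 3 (0.80 log units; beyond the scatter), were both modest, so a modest change is expected here as well, with the direction uncertain. The expected step is a 1.6-fold higher number from compound 3 to compound 4 (0.20 log units; within the scatter). Compound 4 is therefore estimated at 4000 nM, within a range from 1200 nM to 13000 nM.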

Compound 4, half-maximal inhibitory concentration: 1900 nM
For compound 4 the middle estimate is 2.1-fold (0.32 log units) above the measured one; the range from low to high includes it.
By their numbers in this assay, from the lowest: compound 2; then compounds 4 and 3 (each within the scatter of the next); then compound 1.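

In this assay taking the acetyl off this oxygen gives a 1.3-fold lower number from compound 3 to compound 4 (0.12 log units; within the scatter) and thus no real change: at the end of this chain, hydroxy and acetoxy cannot be told apart. The 3-hydroxypropyl chain therefore stands where the 3-acetoxypropyl chain stood, with a 4.8-fold higher number from compound 2 to compound 4 (0.68 log units; beyond the scatter) against the allyl group and a 4.0-fold lower number from compound 1 to compound 4 (0.60 log units; beyond the scatter) against the methoxy group. Nothing measured here accounts for these steps.

Still open, from the compounds shown here alone, is what an amine or a carboxylic acid at the end of this chain would do. Going by these compounds, a longer or shorter chain carrying the same hydroxy is equally open.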